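The source may report more compounds than this note shows. Statements on the series, on what has been measured and on what is new or still open speak of the compounds shown alone.

Three compounds share one core and differ only in the substituent on a phenyl ring attached to it. Compound 1 `O=C(CCCCCCc1ccccc1)c1ncc(-c2cccc(O)c2)o1` carries a 3-hydroxyphenyl, and in an assay (Rattus norvegicus) for inhibition of Fatty-acid amide hydrolase 1 (Homo sapiens) (on this read-out lower numbers stand for stronger inhibition and higher numbers for weaker inhibition), compound 1 gives 50 nM. Compound 2 `O=C(CCCCCCc1ccccc1)c1ncc(-c2ccc([N+](=O)[O-])cc2)o1` carries a 4-nitrophenyl, and in this assay compound 2 gives 50 nM. Compound 3 `O=C(O)c1ccc(-c2cnc(C(=O)CCCCCCc3ccccc3)o2)cc1` carries a 4-carboxyphenyl, and in this assay compound 3 gives 60 nM. On the bare numbers compound 3 sits at the top of the three, yet a 1.2-fold higher number from compound 1 to compound 3 (0.08 log units; within the scatter) and a 1.2-fold higher number from compound 2 to compound 3 (0.08 log units; within the scatter), so the three cannot be told apart; likewise no change at the digits printed from compound 1 to compound 2 (within the scatter).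

Compound 4 `NC(=O)c1ccc(-c2cnc(C(=O)CCCCCCc3ccccc3)o2)cc1` differs from compound 3 by amino in place of hydroxy on a carbonyl carbon. Among the measured compounds shown here, no measured step exchanges these two groups. For the measured compounds named here, the steps that bear on it are the three swaps of the substituent on the phenyl ring, each of which left the number within the scatter. Compound 4 is therefore expected to show no step beyond the scatter, no change at the digits printed from compound 3 to compound 4 (within the scatter). The estimate for compound 4 in this assay is 60 nM, with a range from 30 nM to 130 nM.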

Compound 4, inhibition constant: 10 nM
Estimate against measurement, compound 4: 6.0-fold (0.78 log units) above; the whole stated range lies above it.
By their numbers in this assay, from the lowest: compound 4; then compounds 1, 2 and 3 (each within the scatter of the next).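

In this assay, the substituent on the phenyl ring turns out to be able to shift the number after all: amino in place of hydroxy on a carbonyl carbon gives a clear step (a 6.0-fold lower number from compound 3 to compound 4 (0.78 log units; beyond the scatter)), although the three earlier substituents had stayed within the scatter of one another. The 4-carbamoylphenyl group also separates from the other two (a 5.0-fold lower number from compound 2 to compound 4 (0.70 log units; beyond the scatter); a 5.0-fold lower number from compound 1 to compound 4 (0.70 log units; beyond the scatter)), which leaves compound 4 with the lowest number of the four, even though the computed hydrogen-bond donor and acceptor counts of the exchanged groups are identical. Nothing measured here accounts for this difference. On these data alone, whether a methyl ester or a dimethylcarbamoyl group in the same place would fall with compound 3 or with compound 4 remains open. So does the outcome for a sulfonamide there.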